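Phenyl for dimethoxyphenyl on a second benzimidazole core

A few compounds are considered here, and "the series" means these few. Any claim that something is new, unique, unknown or untested is made for them only; others in the source may bear on it.

Three biaryl benzimidazoles have been tested in a functional assay on SiHa cells (Homo sapiens) for inhibition, read by sulforhodamine B assay; on this read-out higher numbers stand for weaker inhibition of growth and lower numbers for stronger inhibition of growth. Compound 1 `COc1ccc(-c2ccc(-c3ccc(-c4nc5cc(C)ccc5[nH]4)cc3)cc2)cc1OC` gives 3510 nM. Compound 3 `COc1ccc(-c2ccc(-c3ccc(-c4nc5c(O)cccc5[nH]4)cc3)cc2)cc1OC` gives 1110 nM, and compound 2 `Oc1cccc2[nH]c(-c3ccc(-c4ccc(-c5ccccc5)cc4)cc3)nc12` gives 9710 nM. Compound 4 `Cc1ccc2[nH]c(-c3ccc(-c4ccc(-c5ccccc5)cc4)cc3)nc2c1` has not yet been measured.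

Compounds 1 and 3 share the terminal 3,4-dimethoxyphenyl group and differ only in their cores; the difference is 5-methyl-1H-benzimidazol-2-yl in place of 4-hydroxy-1H-benzimidazol-2-yl on an aromatic carbon. That change gave a 3.2-fold lower number from compound 1 to compound 3 (0.50 log units; beyond the scatter).

Within the series of compound 3, one change is already measured: phenyl in place of 3,4-dimethoxyphenyl on an aromatic carbon. This gave an 8.7-fold higher number from compound 3 to compound 2 (0.94 log units; beyond the scatter). Compound 4 carries the same change on the core of compound 1: phenyl in place of 3,4-dimethoxyphenyl on an aromatic carbon. The place of the change is described in the same words in both pairs, so it is counted as the same change.

Within the data shown here, the only guide for compound 4 is the single step from compound 3 to compound 2, which weakened growth inhibition by a modest amount. On that basis it is expected that compound 4 will show a step of a 6.3-fold higher number from compound 1 to compound 4 (0.80 log units; beyond the scatter) in this assay, somewhat smaller than the measured one since it rests on one example. Compound 4 is therefore estimated at 22000 nM. Its range is expected to run from 8000 nM to 60000 nM for compound 4.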

Compound 4, concentration for 50% growth inhibition: 35200 nM
The estimate for compound 4 lay 1.6-fold (0.20 log units) below the measured number, and the stated range covers the measured number.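

In this assay, putting phenyl in place of 3,4-dimethoxyphenyl on the second core gave a 10-fold higher number from compound 1 to compound 4 (1.00 log units; beyond the scatter), and the two readings of this change can now be set side by side: the same change on two cores in this assay, an 8.7-fold higher number (0.94 log units; beyond the scatter) from compound 3 to compound 2 and a 10-fold higher number (1.00 log units; beyond the scatter) from compound 1 to compound 4, 1.1-fold (0.06 log units) apart, within the scatter of two such steps

The change therefore carried over from one core to the other in this series, weakening growth inhibition on both cores by a size that the two pairs do not distinguish. Among these compounds, this rests on only two pairs in a single cell assay, so it does not show that the step would keep its size on any further core, and it gives no reason for the loss of growth inhibition.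

The compounds shown leave open whether both methoxy groups are needed, since the change removes them together and the terminal ring is seen only with both or with neither. They also leave open how a terminal ring carrying a single methoxy group, an amine or a carboxylic acid would read in this assay, and whether any such group would recover the growth inhibition seen with 3,4-dimethoxyphenyl on either core.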